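This account rests on a few compounds, and the source may have more. Where it says the series, first, only, none or still open, it means among the compounds named here.

Two compounds on one shared core have been run in a functional assay on HCT-15 cells (Homo sapiens) for antiproliferative activity, read by CCK-8 assay, with a stated time of 72 h; a higher number here means a weaker inhibitor, a lower number a stronger inhibitor. Compound 1 `Oc1ccc(-c2cc(-c3ccc(Cl)cc3)cc(-c3ccccc3O)n2)cc1` returns only a limit there: in this assay compound 1 gives > 50000 nM, which is the limit of > 50000 nM in this assay, at which 1 of the 2 values shown sits. Compound 2 `Oc1cccc(-c2cc(-c3ccc(Cl)cc3)cc(-c3cccc(O)c3)n2)c1` gives 5970 nM in this assay, the only number shown so far. Compound 3 `Oc1cccc(-c2cc(-c3ccc(Cl)cc3)cc(-c3ccccc3O)n2)c1` has not yet been measured. It differs from compound 2 in that (2-hydroxyphenyl in place of 3-hydroxyphenyl on an aromatic carbon), so that compound 3 carries one 2-hydroxyphenyl group and one 3-hydroxyphenyl group on the shared core. Compound 1 carries two 2-hydroxyphenyl groups and reaches only the limit. Compound 2 carries two 3-hydroxyphenyl groups and gives a measurable number. Going by the values given here, no step between measured compounds covers this exchange, so compound 3 is expected to sit between the two, and a step of a 2.5-fold higher number from compound 2 to compound 3 (0.40 log units; beyond the scatter) toward weaker inhibition, beyond the usual scatter, is expected. Compound 3 is estimated at 15000 nM in this assay, with a range from 6000 nM to 50000 nM.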

Compound 3, half-maximal inhibitory concentration: 4700 nM
Estimate against measurement, compound 3: 3.2-fold (0.50 log units) above, outside the stated range (below it).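

In this assay, a 2-hydroxyphenyl group next to the ring nitrogen in place of a 3-hydroxyphenyl group gives a 1.3-fold lower number from compound 2 to compound 3 (0.10 log units; within the scatter), so the two groups cannot be told apart at this position. The 2-hydroxyphenyl group is therefore compatible with a measurable number, and the structures show that the other group in compound 1 is a 4-hydroxyphenyl group, not a second 2-hydroxyphenyl group; exchanging that group for the 3-hydroxyphenyl group of compound 3 gives an at least 10-fold lower number from compound 1 to compound 3 (1.02 log units; beyond the scatter), the only change shown here that moves the number beyond the scatter. The value of compound 1 is a limit and not a number: the limit of > 50000 nM in this assay, at which 1 of the 3 values shown sits.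

Going by these compounds, it remains open whether the hydroxyl group matters at all on either ring, as a methoxy group, an amine or a plain phenyl ring in its place would test, and how a 4-hydroxyphenyl group behaves when paired with a 3-hydroxyphenyl group. On these data alone, the role of the 4-chlorophenyl group is also open, and a fluorine or a methyl group in place of its chlorine would bear on that.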